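The source may hold more compounds than are shown below. What is called first, only, known or untested is meant among the compounds shown, and "the series" means these compounds.

Of the compounds shown here, two built on one shared core have so far been tested in a functional assay on MCF7 cells (Homo sapiens) for inhibition, read by MTT assay, with a stated time of 72 h; on this read-out lower numbers stand for stronger inhibition and higher numbers for weaker inhibition. Compound 1 `COc1cc(OC)c(OC)cc1/C=C/C(=O)c1ccc(C)cc1` gives 33000 nM in this assay. Compound 2 `COc1cc(OC)c(OC)cc1/C=C/C(=O)c1cc(OC(C)=O)ccc1OC(C)=O` gives 63700 nM in this assay, and the two numbers lie within the usual scatter of repeated measurements of each other, so neither compound stands apart from the other; compound 1 simply sits at one end of a pair that cannot be told apart. Compound 3 `COc1cc(OC)c(OC)cc1/C=C/C(=O)c1ccc(Cl)cc1` is still to be measured in this assay. It differs from compound 1 by chloro in place of methyl on an aromatic carbon. Among the measured compounds shown here, no measured pair shows this same change, so nothing yet tells how it plays out here, and the step from compound 1 is expected to be small, none beyond the scatter, with its direction left open, as a 1.2-fold lower number from compound 1 to compound 3 (0.07 log units; within the scatter) expresses. Compound 3 is therefore expected to give about 28000 nM in this assay, most plausibly between 9000 nM and 90000 nM.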

Compound 3, half-maximal inhibitory concentration: 29500 nM
The estimate for compound 3 lay 1.1-fold (0.02 log units) below the measured number; low and high end bracket the measured number.
By their numbers in this assay, from the lowest: compounds 3, 1 and 2 (each within the scatter of the next, the first and the last beyond it).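

Among the compounds shown here, the first single-place comparison on this core comes from chloro in place of methyl on an aromatic carbon: in this assay, this gives a 1.1-fold lower number from compound 1 to compound 3 (0.05 log units; within the scatter). At this place, para to a large group, the 4-methylphenyl and 4-chlorophenyl compounds therefore cannot be told apart on this read-out. No outside measurement bears on this result, so what lies behind the match remains unknown.

Methyl and chloro each add a single heavy atom here, so it remains open whether something quite different at this place, such as an amine, a carboxylic acid or a longer chain like butyl, would move the number beyond the scatter. Going by these compounds, it is also open whether the same swap would give a similar result on a different core.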